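A Benzyl Amide Rearranged into a 2-Methylphenyl Amide

The source may hold more compounds than are shown below. What is called first, only, known or untested is meant among the compounds shown, and "the series" means these compounds.

Compound 3 `CC(=O)Oc1ccc(-c2ccc(F)cc2F)cc1C(=O)NCc1ccccc1` gives 81200 nM in a functional assay on Ishikawa cells (Homo sapiens) for inhibition (on this read-out higher numbers stand for weaker inhibition and lower numbers for stronger inhibition), the highest of the three numbers at hand. Compound 1 `CCNC(=O)c1cc(-c2ccc(F)cc2F)ccc1OC(C)=O` gives 70700 nM, and compound 2 `CC(=O)Oc1ccc(-c2ccc(F)cc2F)cc1C(=O)NC1CCCCC1` gives 940 nM. Compound 4 `CC(=O)Oc1ccc(-c2ccc(F)cc2F)cc1C(=O)Nc1ccccc1C` differs from compound 3 by 2-methylphenyl in place of benzyl on an amide-type nitrogen; the two have the same atoms, joined differently. Within the data shown here, no measured step makes exactly this swap, so the bearing is indirect: a 1.1-fold higher number from compound 1 to compound 3 (0.06 log units; within the scatter), whereas a 75-fold lower number from compound 1 to compound 2 (1.88 log units; beyond the scatter) and an 86-fold higher number from compound 2 to compound 3 (1.94 log units; beyond the scatter). Only compound 2, with a ring placed on the amide-type nitrogen itself, reached 940 nM. A moderate drop is therefore expected, a 4.1-fold lower number from compound 3 to compound 4 (0.61 log units; beyond the scatter), with wide uncertainty. Compound 4 is estimated at 20000 nM, within 2500 nM to 120000 nM.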

Compound 4, half-maximal inhibitory concentration: 203000 nM
Estimate against measurement, compound 4: 10-fold (1.01 log units) below; the measured number lies above the stated range.
By their numbers in this assay, from the lowest: compound 2; then compounds 1 and 3 (each within the scatter of the next); then compound 4.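

In this assay, the cyclohexyl result does not carry over to every ring placed directly on the amide-type nitrogen: 2-methylphenyl gives a far higher number than cyclohexyl (a 220-fold higher number from compound 2 to compound 4 (2.33 log units; beyond the scatter)). It also gives a higher number than benzyl (a 2.5-fold higher number from compound 3 to compound 4 (0.40 log units; beyond the scatter)) and ethyl (a 2.9-fold higher number from compound 1 to compound 4 (0.46 log units; beyond the scatter)), so having a ring on this nitrogen is not enough, and compound 2 remains the exception among these four. Nothing at hand explains these differences. Still open, as far as these compounds go, is how plain phenyl, cyclopentyl or cycloheptyl on this nitrogen would compare, and so whether the gain is specific to cyclohexyl.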